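Configuration step from compound 2 to compound 4

The compounds below may be only part of what the source reports. "The series", "measured", "known", "first", "only" and "open" are said of these compounds alone.

Values in a functional assay on HL-60 cells (Homo sapiens) for antiproliferative activity (on this read-out lower numbers stand for stronger inhibition and higher numbers for weaker inhibition), so far:
- compound 1 `COc1cc(/C=C/c2ccc([N+](=O)[O-])cc2)cc(OC)c1` gives 35000 nM
- compound 2 `COc1cccc(/C=C/c2cc(OC)cc(OC)c2)c1` gives 37000 nM
- compound 3 `Cc1ccc(/C=C/c2ccc(O)cc2)cc1C` gives 3500 nM

Compound 2 stands level with compound 1 within the scatter, and the two share the high end of the three numbers. Compound 3 lies clearly lower than both.

The next compound to be tested in this assay is compound 4 `COc1cccc(/C=C\c2cc(OC)cc(OC)c2)c1` and its relation to compound 2 is simple: the two compounds have the same atoms and bonds and differ only in configuration as drawn: 1 of 1 stereo elements differ; a double bond is drawn E in compound 2 and Z in compound 4 and nothing leaves or enters. A double bond is drawn E in compound 2 and Z in compound 4.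

Among the compounds with values here, all three measured compounds are drawn E, so the data hold no measured pair that shows what this change does. Any expectation is therefore loose. Within the data shown here, compound 3 at 3500 nM shows only that a compound of this small set can reach a much lower number than compound 2, although it differs from compound 2 in more than configuration.

The expected change is a 6.2-fold lower number from compound 2 to compound 4 (0.79 log units; beyond the scatter) and is taken to run toward stronger inhibition, beyond the scatter. For compound 4 the estimated value is 6000 nM with an expected range from 600 nM to 40000 nM in this assay.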

Compound 4, half-maximal inhibitory concentration: 2800 nM
Beside the measured number, compound 4's estimate is 2.1-fold (0.33 log units) above it, and the stated range covers the measured number.
By their numbers in this assay, from the lowest: compounds 4 and 3 (each within the scatter of the next); then compounds 1 and 2 (each within the scatter of the next).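

In this assay the series now holds its first pair that isolates the double bond, and that pair reads a 13-fold lower number from compound 2 to compound 4 (1.12 log units; beyond the scatter). The earlier compounds shown here were all drawn E and differed from each other in more than one place, so they could not show that this double bond is itself a place where the read-out responds, and strongly, with all three methoxy groups left untouched. The step can be assigned to the double bond alone, and to no substituent, because of one plain structural fact: the fact that compounds 2 and 4 differ only in the configuration as drawn.

Going by these compounds, the step rests on this single pair, so it remains open whether the move from E to Z gives a step of similar size and direction with other substituents, such as the nitro group of compound 1 or the hydroxyl and methyl groups of compound 3. Also open, on these data alone, is how the Z compound 4 responds when one of its methoxy groups gives way to a different group, for example an amine or a carboxylic acid, and why the configuration matters at all.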